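Swapping Acetamidophenyl for Dichlorophenyl: Expected Cytotoxicity

The compounds below may be only part of what the source reports. "The series", "measured", "known", "first", "only" and "open" are said of these compounds alone.

Of the compounds shown here, three built on one shared core have been tested in a functional assay on MCF7 cells (Homo sapiens) for cytotoxicity, read by MTT assay, with a stated time of 48 h; on this read-out higher numbers stand for an effect only at larger amounts of compound and lower numbers for an effect already at smaller amounts. Compound 1 `Cc1c(O)c(=O)ccn1CC(=O)N/N=C1\C(=O)N(CC(=O)Nc2ccc(Br)cc2)c2ccccc21` gives 32500 nM. Compound 2 `CC(=O)Nc1ccc(NC(=O)CN2C(=O)/C(=N\NC(=O)Cn3ccc(=O)c(O)c3C)c3ccccc32)cc1` gives 51900 nM. Compound 3 `Cc1c(O)c(=O)ccn1CC(=O)N/N=C1\C(=O)N(CC(=O)Nc2ccc(Cl)cc2Cl)c2ccccc21` gives 43200 nM. Compound 2 stands no further from the other two than repeated measurements of this kind would allow: there is a 1.6-fold higher number from compound 1 to compound 2 (0.20 log units; within the scatter) and a 1.2-fold lower number from compound 2 to compound 3 (0.08 log units; within the scatter), both within the scatter.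

Compound 4 `Cc1c(O)c(=O)ccn1CC(=O)N/N=C1\C(=O)N(CC(=O)Nc2cc(Cl)cc(Cl)c2)c2ccccc21` has not yet been measured. It differs from compound 2 in one place: 3,5-dichlorophenyl in place of 4-acetamidophenyl on an amide-type nitrogen. The nearest guide is the step from compound 2 to compound 3, in which the same acetamidophenyl gives way to another dichlorophenyl without leaving the scatter; the step of a 1.3-fold higher number from compound 1 to compound 3 (0.12 log units; within the scatter) likewise exchanges only the aryl group and stays within the scatter. On this basis the change to compound 4 is expected to shift this assay by no more than the scatter, a 1.2-fold lower number from compound 2 to compound 4 (0.09 log units; within the scatter). Compound 4 is therefore estimated at 42000 nM, with a likely range from 20000 nM to 90000 nM.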

Compound 4, half-maximal effective concentration: 35100 nM
Estimate against measurement, compound 4: 1.2-fold (0.08 log units) above, within the range that was stated.
By their numbers in this assay, from the lowest: compounds 1, 4, 3 and 2 (each within the scatter of the next).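

In this assay, the step from the acetamido compound to a second dichlorophenyl compound stays within the scatter, with a 1.5-fold lower number from compound 2 to compound 4 (0.17 log units; within the scatter), even though the hydrogen-bond donor and acceptor counted for 4-acetamidophenyl are absent from 3,5-dichlorophenyl. The two chlorines can also be arranged differently without leaving the scatter, as 2,4-dichlorophenyl gives way to 3,5-dichlorophenyl with a 1.2-fold lower number from compound 3 to compound 4 (0.09 log units; within the scatter), and the exchange of 4-bromophenyl for 3,5-dichlorophenyl gives a 1.1-fold higher number from compound 1 to compound 4 (0.03 log units; within the scatter). All four aryl groups on this amide-type nitrogen therefore cannot be told apart in this assay, and no supporting data offer an explanation for this.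

Still open, going by these compounds, is whether an amine or a carboxylic acid on the aromatic ring would move the number beyond the scatter. The same question applies to a longer chain in place of the aryl group.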